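Swapping the aryl group in a cytotoxicity-quiet amide series

The source may hold more compounds than are shown below. What is called first, only, known or untested is meant among the compounds shown, and "the series" means these compounds.

Compound 3 `CCOC(=O)CCCCCOc1cccc(CN(C(=O)c2ccc(-c3ccc(C(C)=O)s3)cc2)C(C)C)c1` was tested in an ADME assay on BJ cells (Homo sapiens) for cytotoxicity, read by CellTiter-Glo and resazurin assay, with a stated time of 72 h (on this read-out higher numbers stand for an effect only at larger amounts of compound and lower numbers for an effect already at smaller amounts), where compound 3 gives > 26000 nM, a limit of the assay rather than a number. Its companions behave alike: compound 1 `CC(C)N(Cc1cccc(OCCCCCC(=O)O)c1)C(=O)c1ccc(-c2cccc(C(F)(F)F)c2)cc1` gives > 26000 nM. Compound 2 `CCOC(=O)CCCCCOc1cccc(CN(C(=O)c2ccc(-c3ccco3)cc2)C(C)C)c1` gives > 26000 nM. Within the data shown here, both of these are limits too, so the limit of > 26000 nM in this assay, at which 3 of the 3 values shown sit, covers every value so far, and the step that the two limits leave unreadable from compound 2 to compound 3 cannot be sized. Compound 4 `CCOC(=O)CCCCCOc1cccc(CN(C(=O)c2ccc(-c3cccc(C(F)(F)F)c3)cc2)C(C)C)c1` differs from compound 3 by 3-(trifluoromethyl)phenyl in place of 5-acetylthiophen-2-yl on an aromatic carbon. Among the measured compounds shown here, no measured step bearing on this change is readable, and compound 1, which already carries the entering group, sits at the same limit. Compound 4 is therefore expected to give 40000 nM, with an estimated range from 20000 nM to 100000 nM. The expected step is a step that the limit leaves unreadable from compound 3 to compound 4, most likely again hidden behind the limit.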

Compound 4, half-maximal effective concentration: < 1.3 nM
Compound 4: no number, only a limit (the forecaster's own chance of this, stated with the estimate: 85%); at least 30000-fold (4.48 log units) between middle value and limit.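

In this assay, this position turns out not to be silent: with the ethyl ester kept, 3-(trifluoromethyl)phenyl gives an at least 20000-fold lower number from compound 3 to compound 4 (4.30 log units; beyond the scatter), and against furan-2-yl it gives an at least 20000-fold lower number from compound 2 to compound 4 (4.30 log units; beyond the scatter). The aryl group alone does not account for this, since compound 1 carries the same group as a carboxylic acid, and the ethyl ester gives an at least 20000-fold lower number from compound 1 to compound 4 (4.30 log units; beyond the scatter). Among these compounds, only the pairing of this aryl group with the ethyl ester reaches the low end, and compound 4 sits at a limit: the limit of < 1.3 nM in this assay, at which 1 of the 4 values shown sits.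

Going by these compounds, the true value of compound 4 stays open. So does whether a plain phenyl with the ethyl ester, or a methyl ester with 3-(trifluoromethyl)phenyl, would behave the same way.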